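The source may hold more compounds than are shown below. What is called first, only, known or untested is meant among the compounds shown, and "the series" means these compounds.

Measured compounds in a functional assay for activation of Alpha-1D adrenergic receptor (Homo sapiens); on this read-out lower numbers stand for an effect already at smaller amounts and higher numbers for an effect only at larger amounts of compound:
compound 1, `Cc1nc(-c2ccccc2NCC2=NCCN2)cs1`: < 5020 nM
compound 2, `c1csc(-c2ccccc2NCC2=NCCN2)c1`: 18.2 nM
compound 3, `Cc1ccc(-c2ccccc2NCC2=NCCN2)o1`: < 2000 nM

Three analogues share one core and differ only in the aromatic ring attached to it. Compound 1 stands at a limit of the assay, < 5020 nM, which is not a number. Compound 2 gives 18.2 nM. Compound 3 is likewise given only as a limit, < 2000 nM. The step that the limit leaves unreadable from compound 1 to compound 2 cannot be sized, and neither can a step that the two limits leave unreadable from compound 1 to compound 3 or a step that the limit leaves unreadable from compound 2 to compound 3. Compound 1 therefore has no fixed place among the values shown: its limit is compatible with a value near that of compound 2 and with a much weaker one.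

Compound 4, `c1ccc(-c2cnccn2)c(NCC2=NCCN2)c1`, is not yet measured. It differs from compound 1 by pyrazin-2-yl in place of 2-methyl-1,3-thiazol-4-yl on an aromatic carbon. The measured steps that bear on this change are the two other ring exchanges starting from compound 1, those to compound 2 and to compound 3; both are unreadable in size, so no direction can be taken from them. The step expected is a step that the limit leaves unreadable from compound 1 to compound 4, with its direction uncertain. Compound 4 is expected to give 300 nM, within a range from 30 nM to 3000 nM.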

Compound 4, half-maximal effective concentration: 182 nM
Beside the measured number, compound 4's estimate is 1.6-fold (0.22 log units) above it, and the stated range covers the measured number.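

In this assay, within the data shown here, compound 4 supplies a second number beside compound 2, so an exchange of the ring on this aromatic carbon can be sized for the first time: pyrazin-2-yl in place of thiophen-2-yl is a 10-fold higher number from compound 2 to compound 4 (1.00 log units; beyond the scatter). On this pair, the ring at this place moves the read-out by a readable amount, and a six-membered aromatic ring still gives a number rather than a limit, though a higher number than the five-membered thiophen-2-yl of compound 2. The steps to compound 4 from compound 1 and from compound 3 cannot be read; those two compounds stand only as limits of the assay.

Thiophen-2-yl and pyrazin-2-yl differ both in ring size and in their hetero atoms, so the pair does not tell which of the two carries the step, and a phenyl or pyridin-2-yl group at this place would separate them. Also open, on these data alone, are the weight of the methyl groups in compound 1 and compound 3, and whether an amine or a carboxylic acid on the pyrazin-2-yl ring would shift the number of compound 4.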